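Solubility Expectation for a Phenethyl Analogue of Compound 3

The source may hold more compounds than are shown below. What is called first, only, known or untested is meant among the compounds shown, and "the series" means these compounds.

Compound 3 `COc1ccc(-c2ccc3c(NCCCNCc4ccco4)ccnc3c2)cc1` stands highest of the three measured compounds in a physicochemical assay for solubility, with a stated time of 18 h, at pH 7.4 (a lower number here means a less soluble compound, a higher number a more soluble compound), where compound 3 gives 32000 nM. Compound 1 `Fc1ccc(Cc2ccc3c(NCCCNCc4ccco4)ccnc3c2)c(Cl)c1` gives 4200 nM and compound 2 `COc1ccc(F)cc1CNCCCNc1ccnc2cc(CCc3ccccc3)ccc12` gives 4200 nM. Among the measured compounds shown here, the only single-point step among them is a 7.6-fold higher number from compound 1 to compound 3 (0.88 log units; beyond the scatter). Compound 4 `c1ccc(CCc2ccc3c(NCCCNCc4ccco4)ccnc3c2)cc1` differs from compound 3 by phenethyl in place of 4-methoxyphenyl on an aromatic carbon. For the measured compounds named here, no measured step covers this exact change, but compound 2 carries the same phenethyl group on its core and shows a markedly lower number than compound 3, and compound 1 shows that a group other than 4-methoxyphenyl at this carbon also sits well below compound 3. Compound 4 is therefore expected to fall back toward those values, a step of a 6.4-fold lower number from compound 3 to compound 4 (0.81 log units; beyond the scatter). The estimate for compound 4 is 5000 nM, with a range from 2000 nM to 15000 nM.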

Compound 4, solubility: 4200 nM
For compound 4 the middle estimate is 1.2-fold (0.08 log units) above the measured one; low and high end bracket the measured number.
By their numbers in this assay, from the lowest: compounds 1, 2 and 4 (each within the scatter of the next); then compound 3.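

Phenethyl in place of 4-methoxyphenyl on this aromatic carbon now has a direct reading in this assay (a 7.6-fold lower number from compound 3 to compound 4 (0.88 log units; beyond the scatter)). Two further differences stay within the scatter: furan-2-yl in place of 5-fluoro-2-methoxyphenyl (no change at the digits printed from compound 2 to compound 4 (within the scatter)) and benzyl in place of 2-chloro-4-fluorophenyl (no change at the digits printed from compound 1 to compound 4 (within the scatter)). No evidence on the cause accompanies these results.

Still open, going by these compounds, is whether the step follows the methoxy group or the two-carbon link of phenethyl. An unsubstituted phenyl on this aromatic carbon would separate the two.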